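A few compounds are considered here, and "the series" means these few. Any claim that something is new, unique, unknown or untested is made for them only; others in the source may bear on it.

Compound 1 `Cc1cn([C@@H]2O[C@H](CO)[C@@H](CN)[C@@H]2O)c(=O)[nH]c1=O`: > 100 uM
Compound 2 `Cc1cn([C@H]2C[C@H](CO)[C@@H](CO)O2)c(=O)[nH]c1=O`: 5 uM

In a functional assay on P388 cells (Mus musculus) for antiproliferative activity, with a stated time of 72 h (on this read-out lower numbers stand for an effect already at smaller amounts and higher numbers for an effect only at larger amounts of compound), compound 1 gives > 100 uM, a limit of the assay rather than a number. Compound 1 thus stands at the limit of > 100 uM in this assay, at which 1 of the 2 values shown sits. Compound 2 gives 5 uM in this assay, a measured number. Compound 3 `Cc1cn([C@@H]2O[C@H](CO)[C@@H](CN=[N+]=[N-])[C@@H]2O)c(=O)[nH]c1=O` differs from compound 1 in one place: azido in place of amino on a saturated chain carbon bound to a saturated ring carbon. The step from compound 1 to compound 3 in this assay is expected to be small and toward lower numbers, an at least 1.2-fold lower number from compound 1 to compound 3 (0.09 log units; that floor lies within the scatter), with no certainty that it exceeds the scatter. Compound 3 is estimated at 80 uM, in the range 20 uM to 300 uM.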

Compound 3, concentration for half-maximal effect: > 100 uM
Compound 3: a limit, no number; the forecaster's own chance of this, stated with the estimate: 55%; at least 1.2-fold (0.09 log units) between middle value and limit.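

Compound 1 and compound 3 both rest on a limit in this assay, and the step between them cannot be read: the limit of > 100 uM in this assay, at which 2 of the 3 values shown sit. The compounds shown leave open how far either lies from that limit, and whether azido in place of amino changes the read-out at all.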